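The source may hold more compounds than are shown below. What is called first, only, known or untested is meant among the compounds shown, and "the series" means these compounds.

Measured in a physicochemical assay for solubility, in phosphate buffer, with a stated time of 18 h, at pH 7; on this read-out lower numbers stand for lower solubility and higher numbers for higher solubility:
- Compound 1 `CC(C)CN1C(=O)c2ccccc2[C@H](C(=O)Nc2ccc(F)c(C#N)c2)[C@H]1c1ccsc1`: < 1000 nM, a limit
- Compound 2 `CC(C)CN1C(=O)c2ccccc2[C@H](C(=O)Nc2ccc(F)c(C#N)c2)[C@H]1c1ccco1`: 13000 nM

Among the measured compounds shown here, compound 2 holds the only exact number so far. Compound 3 `CC(C)CN1C(=O)c2ccccc2[C@H](C(=O)Nc2ccc(F)c(C#N)c2)[C@H]1c1ccnnc1` differs from it at one place: pyridazin-4-yl in place of furan-2-yl on a saturated ring carbon. For the measured compounds named here, the one measured step that bears on this is an at least 13-fold higher number from compound 1 to compound 2 (1.11 log units; beyond the scatter), a large step at the same saturated ring carbon. It shows that swapping this ring can move the read-out far, but this single step cannot fix the direction for pyridazin-4-yl. A further upward move, somewhat smaller, is expected in this assay. The expected step is a 3.1-fold higher number from compound 2 to compound 3 (0.49 log units; beyond the scatter). For compound 3 the estimate is 40000 nM, with an expected range of 13000 nM to 120000 nM.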

Compound 3, solubility: 28000 nM
Beside the measured number, compound 3's estimate is 1.4-fold (0.15 log units) above it; the measured number falls inside the stated range.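

In this assay, the saturated ring carbon next to the ring nitrogen accepts a six-membered aromatic ring, and pyridazin-4-yl in place of furan-2-yl gives a 2.2-fold higher number from compound 2 to compound 3 (0.33 log units; beyond the scatter). Pyridazin-4-yl in place of thiophen-3-yl gives an at least 28-fold higher number from compound 1 to compound 3 (1.44 log units; beyond the scatter). That second step is open-ended, as it rests on a limit: the limit of < 1000 nM in this assay, at which 1 of the 3 values shown sits.

The compounds shown leave open how pyridin-4-yl or a morpholine ring would read at this carbon. They also leave open whether these ring changes hold with a longer chain in place of the isobutyl group.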